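The source may hold more compounds than are shown below. What is called first, only, known or untested is meant among the compounds shown, and "the series" means these compounds.

Compound 2 `COc1ccc2c(OCC[C@@H]3NC(=O)N(C)CCCC/C=C\[C@@H]4C[C@@]4(C(=O)NS(=O)(=O)C4(C)CC4)NC3=O)cc(-n3ccc(C(C)C)n3)nc2c1C` carries a 3-isopropyl-1H-pyrazol-1-yl group on its core, and in an ADME assay on cells (Homo sapiens) for activation (a lower number here means that less compound is tolerated, a higher number that more compound is tolerated), compound 2 gives 25600 nM. Its number sits within the scatter of that of compound 1 `COc1ccc2c(OCC[C@@H]3NC(=O)N(C)CCCC/C=C\[C@@H]4C[C@@]4(C(=O)NS(=O)(=O)C4CC4)NC3=O)cc(-c3nc(C(C)C)cs3)nc2c1Cl`, which in this assay gives 40400 nM. Compound 3 `COc1ccc2c(OCC[C@@H]3NC(=O)N(C)CCCC/C=C\[C@@H]4C[C@@]4(C(=O)NS(=O)(=O)C4CC4)NC3=O)cc(-c3nc(C(C)C)cs3)nc2c1F` differs from compound 1 only by fluoro in place of chloro on an aromatic carbon. In this assay compound 3 reaches only a limit, > 75000 nM, and not a number. That step, an at least 1.8-fold higher number from compound 1 to compound 3 (0.26 log units; that floor lies within the scatter), is the one measured step shown, and it rests on (the limit of > 75000 nM in this assay, at which 1 of the 3 values shown sits).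

Compound 4 `CCn1cc(-c2cc(OCC[C@@H]3NC(=O)N(C)CCCC/C=C\[C@@H]4C[C@@]4(C(=O)NS(=O)(=O)C4(C)CC4)NC3=O)c3ccc(OC)c(C)c3n2)cn1` is made from compound 2 by 1-ethyl-1H-pyrazol-4-yl in place of 3-isopropyl-1H-pyrazol-1-yl on an aromatic carbon. Among the compounds with values here, no measured step touches this kind of exchange: the step from compound 1 to compound 3 concerns a halogen on a different ring and so gives no guide here. Nothing shown therefore points to a step beyond the scatter in this assay, in either direction. The expected step from compound 2 to compound 4 is no change at the digits printed from compound 2 to compound 4 (within the scatter). Compound 4 is estimated at 25600 nM, with a range from 10000 nM to 70000 nM.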

Compound 4, half-maximal cytotoxic concentration: 36700 nM
Beside the measured number, compound 4's estimate is 1.4-fold (0.16 log units) below it; the measured number falls inside the stated range.
By their numbers in this assay, from the lowest: compounds 2, 4 and 1 (each within the scatter of the next). At a limit, above all of these: compound 3.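

In this assay, placing 1-ethyl-1H-pyrazol-4-yl instead of 3-isopropyl-1H-pyrazol-1-yl on the aromatic carbon next to the ring nitrogen gives a 1.4-fold higher number from compound 2 to compound 4 (0.16 log units; within the scatter). Within the data shown here, this is the first measured step at this position, since the only earlier step concerned a halogen on a different ring, and it shows that this one exchange of a pyrazole group for another stays within the scatter. The exchange alters both the alkyl group and the way the pyrazole is attached, and nothing shown bears on a cause for the step.

As far as these compounds go, it remains open how each of those two alterations would read alone. From the compounds shown here alone, it also remains open whether a group of another kind at this position, such as an amine or a carboxylic acid, would likewise stay within the scatter.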